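A swap of groups on oxygen: estimating compound 4

This account rests on a few compounds, and the source may have more. Where it says the series, first, only, none or still open, it means among the compounds named here.

Compound 1 `Cc1cc(Br)cc(C)c1Oc1cc(Nc2ccc(C#N)cc2)ncc1[N+](=O)[O-]` gives 12300 nM
Compound 2 `N#Cc1ccc(Nc2cc(Oc3c(Cl)cccc3Cl)c([N+](=O)[O-])cn2)cc1` gives 27700 nM
Compound 3 `N#Cc1ccc(Nc2cc(Oc3c(Cl)cc([N+](=O)[O-])cc3Cl)c([N+](=O)[O-])cn2)cc1` gives 26500 nM

These numbers come from an ADME assay on MT4 cells (Homo sapiens) for inhibition, read by MTT assay, with a stated time of 5 days (on this read-out lower numbers stand for higher toxicity in this test and higher numbers for lower toxicity in this test), and describe how much of each compound it takes to harm the cells. Compound 1 holds the lowest number of the three, which on this read-out means the highest toxicity among them.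

Compound 4 `Cc1cc(Br)c(Oc2cc(Nc3ccc(C#N)cc3)ncc2[N+](=O)[O-])c(Br)c1` has not been measured yet. It carries 2,6-dibromo-4-methylphenyl in place of 4-bromo-2,6-dimethylphenyl on an oxygen on an aromatic ring and otherwise matches compound 1.

The closest guide is a change of the group at that same place, which came out as a 2.3-fold higher number from compound 1 to compound 2 (0.35 log units; beyond the scatter) and counts as a modest move. The other measured change, nitro in place of hydrogen on an aromatic carbon, gave a 1.0-fold lower number from compound 2 to compound 3 (0.02 log units; within the scatter) and so offers little guidance here. Within the data shown here, no measured compound carries the incoming group, so the evidence is indirect.

On the strength of a 2.3-fold higher number from compound 1 to compound 2 (0.35 log units; beyond the scatter) a small rise in this assay is expected, though it may stay within the scatter. The estimated change is a 1.4-fold higher number from compound 1 to compound 4 (0.14 log units; within the scatter) and it could prove smaller still. Compound 4 is expected to read 17000 nM with an estimated range from 8000 nM to 32000 nM once measured.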

Compound 4, half-maximal cytotoxic concentration: 23600 nM
Compound 4: the middle estimate sits 1.4-fold (0.14 log units) below what was measured, and the stated range covers the measured number.
By their numbers in this assay, from the lowest: compounds 1, 4, 3 and 2 (each within the scatter of the next, the first and the last beyond it).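

In this assay, moving from 4-bromo-2,6-dimethylphenyl to 2,6-dibromo-4-methylphenyl on the oxygen gives a 1.9-fold higher number from compound 1 to compound 4 (0.28 log units; within the scatter) and so stays inside the scatter, even though the earlier change at this place, to 2,6-dichlorophenyl, went just beyond it. Measured against that 2,6-dichlorophenyl group, the new group gives a 1.2-fold lower number from compound 2 to compound 4 (0.07 log units; within the scatter), which means compound 4 cannot be told apart from either neighbour, and the one difference that passed the scatter at this place now looks like the two ends of a narrow spread rather than a clear divide between groups. Nothing measured here explains these small differences.

On these data alone, all the groups on this oxygen so far are phenyl rings carrying halogens or methyl, so it remains open whether a phenyl ring carrying an amine or a carboxylic acid would move the number clearly beyond the scatter. As far as these compounds go, it is also open whether a saturated chain such as butyl in place of the ring would leave the number in the same narrow spread.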